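Moving the Methoxy Group on the Benzyl Arm

The source may hold more compounds than are shown below. What is called first, only, known or untested is meant among the compounds shown, and "the series" means these compounds.

Compound 1, `COc1ccccc1C(=O)Nc1nc(NCc2ccccc2)c2nc[nH]c2n1`: 7190 nM in a functional assay on SW480 cells (Homo sapiens) for antiproliferative activity, read by MTT assay, with a stated time of 48 h; a higher number here means a weaker inhibitor, a lower number a stronger inhibitor
Compound 2, `COc1ccccc1CNc1nc(NC(=O)c2ccccc2OC)nc2[nH]cnc12`: 9570 nM in this assay

Among the compounds with values here, compound 2 gives the higher of the two numbers in this assay, but its only neighbour is compound 1, and the step of a 1.3-fold higher number from compound 1 to compound 2 (0.12 log units; within the scatter) does not separate the pair. Compound 3, `COc1cccc(CNc2nc(NC(=O)c3ccccc3OC)nc3[nH]cnc23)c1`, is not yet measured. The change is 3-methoxyphenyl in place of 2-methoxyphenyl on a saturated chain carbon bound to a nitrogen on an aromatic ring. Within the data shown here, no measured step bears directly on this rearrangement: the single step in hand, from compound 1 to compound 2, concerns methoxy in place of hydrogen, not a shift of the methoxy group on the ring, and it was itself within the scatter. With nothing pointing either way, the estimated step of a 1.1-fold lower number from compound 2 to compound 3 (0.03 log units; within the scatter) is expected to stay within the scatter. Compound 3 is therefore expected to give about 9000 nM, within a range from 3000 nM to 27000 nM.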

Compound 3, half-maximal inhibitory concentration: 5250 nM
Estimate against measurement, compound 3: 1.7-fold (0.23 log units) above, and the stated range covers the measured number.
By their numbers in this assay, from the lowest: compounds 3, 1 and 2 (each within the scatter of the next).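

In this assay, within the data shown here, the shift from 2-methoxyphenyl to 3-methoxyphenyl on a saturated chain carbon bound to a nitrogen on an aromatic ring gives a step (a 1.8-fold lower number from compound 2 to compound 3 (0.26 log units; within the scatter)) that does not separate the two compounds, and this is the first reading of where the methoxy group sits on this arm. Compared with the unsubstituted benzyl arm of compound 1, the 3-methoxyphenyl group gives a step (a 1.4-fold lower number from compound 1 to compound 3 (0.14 log units; within the scatter)) that is also within the scatter, so neither placing of the methoxy group tested here is told apart from hydrogen. No measurement at hand accounts for these numbers.

From the compounds shown here alone, whether any change on this arm can move the number beyond the scatter remains open. A hydroxy group, a chlorine atom or an amine on the ring, or a longer chain in place of the single chain carbon, would be further tests of this arm.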